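A few compounds are considered here, and "the series" means these few. Any claim that something is new, unique, unknown or untested is made for them only; others in the source may bear on it.

In an ADME assay on WI-38 cells (Homo sapiens) for cytotoxicity, read by MTT assay, with a stated time of 72 h (a higher number here means a weaker inhibitor, a lower number a stronger inhibitor), compound 1 `O=C(CCc1cccc2c1B(O)OC2)NC1CCCCC1`, with cyclohexyl on the amide nitrogen, gives > 100000 nM, which is a limit and not a number. Compound 2 `O=C(CCc1cccc2c1B(O)OC2)Nc1nccs1`, with 1,3-thiazol-2-yl in that place, gives > 100000 nM, which is also only a limit. For the measured compounds named here, compound 3 `O=C(CCc1cccc2c1B(O)OC2)Nc1ccc(Br)cc1`, carrying 4-bromophenyl there, gives 42000 nM, the only true number of the three and the lowest.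

Compound 4 `CC(C)(C)OC(=O)Nc1ccc(NC(=O)CCc2cccc3c2B(O)OC3)cc1` keeps the shared core and the amide but has (tert-butoxycarbonyl)amino in place of bromo on an aromatic carbon. Going by the values given here, no measured step makes this exact change. The nearest evidence comes from the two readable steps at the amide nitrogen, an at least 2.3-fold lower number from compound 1 to compound 3 (0.37 log units; beyond the scatter) and an at least 2.3-fold lower number from compound 2 to compound 3 (0.37 log units; beyond the scatter), and both end at the bromo compound. Compound 4 keeps the six-membered aromatic ring of carbon only but loses the bromo, and the data do not show which of the two goes with the lower number. A slight lean towards a higher number in this assay is therefore the most that can be expected, and the measurement may return only a limit. The expected change is a 1.5-fold higher number from compound 3 to compound 4 (0.19 log units; within the scatter). For compound 4 the estimated value is 65000 nM, with an expected range of 25000 nM to 100000 nM.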

Compound 4, half-maximal inhibitory concentration: > 100000 nM
Compound 4 was reported as a limit (the forecaster's own chance of this, stated with the estimate: 35%); middle value at least 1.5-fold (0.18 log units) from the limit.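

Replacing bromo with (tert-butoxycarbonyl)amino, a group of 8 heavy atoms, on the aromatic carbon para to a large group gives a readable step in this assay: an at least 2.3-fold higher number from compound 3 to compound 4 (0.37 log units; beyond the scatter). The earlier steps shown here changed the whole group on the amide nitrogen, so they could not separate the six-membered aromatic ring of carbon only from the bromo it carried. Compound 4 keeps that ring yet gives no true number, so the ring alone is not enough for a measurable value here, and compound 3 stands apart from the other compounds shown, with the rest sitting at one shared ceiling: the limit of > 100000 nM in this assay, at which 3 of the 4 values shown sit.

The steps among compound 1, compound 2 and compound 4 cannot be read, so these three cannot be placed in order. Going by these compounds, it also remains open whether the lower number of compound 3 belongs to bromo in particular, or whether chloro, methyl or the free amine at the same place would give a true number too, and whether (tert-butoxycarbonyl)amino differs from these smaller groups at all.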